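Hydrogen in place of 2-chlorophenyl on the aromatic nitrogen

This account rests on a few compounds, and the source may have more. Where it says the series, first, only, none or still open, it means among the compounds named here.

In an ADME assay on Huh-7 cells (Homo sapiens) for cytotoxicity, read by MTT assay, with a stated time of 72 h (on this read-out higher numbers stand for lower toxicity in this test and lower numbers for higher toxicity in this test), compound 2 `Cc1cc(=O)oc2cc(OCc3cn(-c4ccccc4Cl)nn3)ccc12` gives > 100 ug/mL, which is a limit of the assay and not a number. Compound 1 `Cc1cc(=O)oc2cc(OCc3cn(-c4ccc(F)c(Cl)c4)nn3)ccc12` also gives > 100 ug/mL, again a limit. Compound 3 `Cc1cc(F)ccc1-n1cc(COc2ccc3c(C)cc(=O)oc3c2)nn1` likewise gives > 100 ug/mL, a limit as well. All three sit at the limit of > 100 ug/mL in this assay, at which 3 of the 3 values shown sit. The step that the two limits leave unreadable from compound 1 to compound 2, the step that the two limits leave unreadable from compound 1 to compound 3 and the step that the two limits leave unreadable from compound 2 to compound 3 are therefore unreadable, so these three compounds show nothing about how the group on the aromatic nitrogen shifts the half-maximal cytotoxic concentration.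

Compound 4 `Cc1cc(=O)oc2cc(OCc3c[nH]nn3)ccc12` differs from compound 2 as follows: hydrogen in place of 2-chlorophenyl on an aromatic nitrogen. Within the data shown here, no measured step covers this change; the three measured steps swap one aromatic group for another and are unreadable in size, so they give neither a direction nor a magnitude to carry over. Because the limit of > 100 ug/mL in this assay, at which 3 of the 3 values shown sit, holds compound 1, compound 2 and compound 3 alike, the expectation for compound 4 is that it too ends at or near that limit, with no step beyond the scatter. Compound 4 is therefore expected to give 150 ug/mL in this assay, within a range from 60 ug/mL to 400 ug/mL. This estimate means an expected step that the limit leaves unreadable from compound 2 to compound 4.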

Compound 4, half-maximal cytotoxic concentration: > 100 ug/mL
Compound 4 ended at the assay's limit (the forecaster's own chance of this, stated with the estimate: 85%); the middle value does not contradict the limit.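

In this assay compound 4 gives > 100 ug/mL, which is a limit of the assay and not a number. The steps from compound 1, compound 2 and compound 3 to compound 4 therefore cannot be read, as all four compounds rest at one limit: the limit of > 100 ug/mL in this assay, at which 4 of the 4 values shown sit.

The compounds shown leave open at what concentration any of them reaches half-maximal cytotoxicity, and whether hydrogen or any of the aromatic groups on the aromatic nitrogen shifts that concentration.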